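The compounds below may be only part of what the source reports. "The series", "measured", "known", "first", "only" and "open" are said of these compounds alone.

Measured so far:
- Compound 1 `CC(C)(C)n1cc2c(n1)C(=O)CC1(CCN(C(=O)c3cc(-c4ccc(Br)cc4)nc4ccccc34)CC1)O2`: 9300 nM
- Compound 2 `CC(C)(C)n1cc2c(n1)C(=O)CC1(CCN(C(=O)c3cc(-c4ccncc4)nc4ccccc34)CC1)O2`: 550 nM
- Compound 3 `CN1CCN(c2cc(C(=O)N3CCC4(CC3)CC(=O)c3nn(C(C)(C)C)cc3O4)c3ccccc3n2)CC1`: > 10000 nM, a limit of the assay and not a number

These three compounds share one core and differ only in the group on one aromatic carbon. All were tested in a functional assay on A549 cells (Homo sapiens) for inhibition, read by MTT assay, with a stated time of 72 h; a lower number here means a stronger inhibitor, a higher number a weaker inhibitor. Compound 3 has no exact number, only a limit: the limit of > 10000 nM in this assay, at which 1 of the 3 values shown sits.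

Compound 4 `COc1cc(C(=O)N2CCC3(CC2)CC(=O)c2nn(C(C)(C)C)cc2O3)c2ccccc2n1` has methoxy in place of 4-methylpiperazin-1-yl on that aromatic carbon, next to the ring nitrogen (methoxy in place of 4-methylpiperazin-1-yl on an aromatic carbon).

Changing the group at this carbon has mattered before. Two measured steps are large: a 17-fold lower number from compound 1 to compound 2 (1.23 log units; beyond the scatter) and an at least 18-fold higher number from compound 2 to compound 3 (1.25 log units; beyond the scatter). The third, an at least 1.0-fold higher number from compound 1 to compound 3 (0.03 log units; that floor lies within the scatter), says little. Within the data shown here, none of the measured compounds carries methoxy, so these steps show how far the number can move, but not firmly which way it will go here.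

Compound 2 at 550 nM shows that a much lower number is possible with a change at this carbon, while compound 1 at 9300 nM shows that a change here can also leave the number high. A moderate move toward a lower number is therefore expected, namely an at least 3.3-fold lower number from compound 3 to compound 4 (0.52 log units; beyond the scatter). The estimate for compound 4 is 3000 nM, with an expected range from 600 nM to 10000 nM.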

Compound 4, half-maximal inhibitory concentration: > 10000 nM
Compound 4: no number, only a limit; the forecaster's own chance of this, stated with the estimate: 25%; middle value at least 3.3-fold (0.52 log units) away from the limit.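

In this assay, methoxy in place of pyridin-4-yl gives an at least 18-fold higher number from compound 2 to compound 4 (1.25 log units; beyond the scatter), so a second group, this time one with no ring, fails to keep the low number seen with pyridin-4-yl. Measured against 4-bromophenyl, methoxy gives an at least 1.0-fold higher number from compound 1 to compound 4 (0.03 log units; that floor lies within the scatter), and as that floor lies within the scatter, this comparison says little. The step between 4-methylpiperazin-1-yl and methoxy cannot be read because both values are limits of the assay and not numbers: the limit of > 10000 nM in this assay, at which 2 of the 4 values shown sit.

Of the four groups at this carbon, pyridin-4-yl alone gives a number well clear of that limit, but the compounds shown cannot tell whether its aromatic ring, its ring nitrogen or both matter. As far as these compounds go, a plain phenyl group and pyridin-3-yl, which has its ring nitrogen in a different place, would help separate these possibilities, and how either of them behaves at this carbon remains open.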